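A methoxy group on compound 1: what to expect

The source may report more compounds than this note shows. Statements on the series, on what has been measured and on what is new or still open speak of the compounds shown alone.

In a functional assay on NCI-H460 cells (Homo sapiens) for inhibition, read by MTT assay, with a stated time of 24 h, tested at 10 ug/mL (on this read-out higher numbers stand for more inhibition of growth at the one concentration tested and lower numbers for less inhibition of growth), compound 1 (`O=C(CCCCC(S)CCS)Nc1ccccc1`) gives 8.37% and compound 2 (`O=C(CCCCC(S)CCS)Nc1cccc(C(F)(F)F)c1`) gives 11.4% and these two numbers are all there is to place compound 1 against. Among the measured compounds shown here, they lie within the usual scatter of each other, so compound 1 cannot be told apart from its single neighbour.

Compound 3 (`COc1ccc(NC(=O)CCCCC(S)CCS)cc1`) differs from compound 1 in one place (methoxy in place of hydrogen on an aromatic carbon), which in words is methoxy in place of hydrogen on an aromatic carbon, para to a large group. For the measured compounds named here, the one measured step that bears on this is a number 3 percentage points higher from compound 1 to compound 2 (within the scatter) and it too replaces a hydrogen on an aromatic carbon, there with trifluoromethyl. Going by the values given here, that step is small, but it involves a different group, no methoxy compound has been measured, and a single step sets no trend. The estimated change is therefore a number 1.6 percentage points higher from compound 1 to compound 3 (within the scatter) and no move beyond the scatter is expected in this assay for this swap. Compound 3 is expected at 10% within an estimated range from 2% to 22% at the one concentration tested.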

Compound 3, percent growth inhibition at one concentration: 1.43%
Beside the measured number, compound 3's estimate is 8.6 percentage points above it; measured number below the stated range.
By their numbers in this assay, from the lowest: compounds 3, 1 and 2 (each within the scatter of the next).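

In this assay the new step is a number 6.9 percentage points lower from compound 1 to compound 3 (within the scatter), so a methoxy group para to a large group cannot be told apart from the hydrogen it replaces. This gives the first measured result for methoxy on the aromatic ring of the shared core, and it is the second replacement of an aromatic hydrogen, after trifluoromethyl, whose step from compound 1 lies within the scatter. The data show no measured property that could account for the value of compound 3, so no cause can be given for it.

From the compounds shown here alone, whether an amine, a carboxylic acid or a longer chain such as ethoxy in this same place would move the number beyond the scatter remains open. Also open, going by these compounds, are whether methoxy would behave the same way elsewhere on the aromatic ring and whether compound 1 and compound 3 would separate at a concentration other than the single one tested.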